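The source may report more compounds than this note shows. Statements on the series, on what has been measured and on what is new or still open speak of the compounds shown alone.

Series notes, cytotoxicity. Three analogues carry the same core with a chloroquinoline-type amine linked through a short chain. Compound 1 `CSc1nc(NCCCNc2ccnc3cc(Cl)ccc23)c(C#N)c(-c2ccccc2)n1` gives 100000 nM in an ADME assay on Vero cells (Chlorocebus sabaeus) for cytotoxicity, read by microscopy; a higher number here means that more compound is tolerated, a lower number that less compound is tolerated. Compound 2 `CSc1nc(NCCCCNc2ccnc3cc(Cl)ccc23)c(C#N)c(-c2ccccc2)n1` gives 20000 nM in this assay, which places compound 2 second highest of the three numbers, beyond the scatter from both neighbours. Compound 3 `CSc1nc(OCCCNc2ccnc3cc(Cl)ccc23)c(C#N)c(-c2ccccc2)n1` gives 4000 nM in this assay, the lowest of the set. No pair among these three differs in only one place, so none of those gaps is read as a single step.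

Compound 4 `CSc1nc(NCCCCNc2ccnc3cc(Cl)ccc23)c(C#N)c(-c2cccc([N+](=O)[O-])c2)n1` differs from compound 2 by nitro in place of hydrogen on an aromatic carbon. Nothing in the measured set shows how such a change affects tolerance, so the expected step of no change at the digits printed from compound 2 to compound 4 (within the scatter) is none beyond the scatter. Compound 4 is therefore estimated at 20000 nM in this assay, within 7000 nM to 60000 nM.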

Compound 4, minimum cytotoxic concentration: 20000 nM
For compound 4 middle estimate and measured number coincide at the digits printed, and the stated range covers the measured number.
By their numbers in this assay, from the lowest: compound 3; then compounds 2 and 4 (each within the scatter of the next); then compound 1.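

In this assay the phenyl to 3-nitrophenyl change gives no change at the digits printed from compound 2 to compound 4 (within the scatter), the first single-place step available in this series. At this position, on an aromatic carbon meta to a large group, nitro in place of hydrogen therefore leaves no step beyond the scatter, at least with the chain of compound 2. Nothing on hand gives a reason for this result. From the compounds shown here alone, whether an amine or a carboxylic acid at the same carbon would read alike remains open. So does whether nitro would behave the same way on the shorter chain of compound 1.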